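The source may report more compounds than this note shows. Statements on the series, on what has been measured and on what is new or still open speak of the compounds shown alone.

Measured so far in an ADME assay on the whole organism (plasma, strain Wistar-Han) for pharmacokinetics, with Rattus norvegicus as the target, at a dose of 1 mg/kg by the intravenous route; on this read-out higher numbers stand for fast clearance and lower numbers for slow clearance
- compound 1 `CCCC(Nc1ccc(-n2cc(C(F)(F)F)cn2)nc1)c1ccc(C(=O)NCCC(=O)O)cc1` gives 74 mL/min/kg
- compound 2 `CCCC(Oc1ccc(-n2cc3ccccc3n2)cc1)c1ccc(C(=O)NCCC(=O)O)cc1` gives 18 mL/min/kg

Compound 2 is the lower of the two, and the gap to compound 1 lies beyond the scatter. Compound 3 `CCCC(Oc1ccc(-n2cc(C(F)(F)F)cn2)cc1)c1ccc(C(=O)NCCC(=O)O)cc1` differs from compound 2 by 4-(trifluoromethyl)-1H-pyrazol-1-yl in place of 2H-indazol-2-yl on an aromatic carbon in one place, with 4-(trifluoromethyl)-1H-pyrazol-1-yl in place of 2H-indazol-2-yl on an aromatic carbon. Among the compounds with values here, no measured pair isolates this change. Compound 1 at 74 mL/min/kg carries the entering group but differs elsewhere as well, so it is only weak support for a rise. A small upward move, not clearly beyond the scatter, is expected for a 1.7-fold higher number from compound 2 to compound 3 (0.22 log units; within the scatter) in this assay as the step. For compound 3 the estimated value is 30 mL/min/kg (expected range 13 mL/min/kg to 65 mL/min/kg).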

Compound 3, clearance: 17 mL/min/kg
The estimate for compound 3 lay 1.8-fold (0.25 log units) above the measured number, within the range that was stated.
By their numbers in this assay, from the lowest: compounds 3 and 2 (each within the scatter of the next); then compound 1.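

Within the data shown here, on the aromatic carbon para to a large group, the first isolated change in this assay gives a 1.1-fold lower number from compound 2 to compound 3 (0.02 log units; within the scatter), so 4-(trifluoromethyl)-1H-pyrazol-1-yl and 2H-indazol-2-yl cannot be told apart on this read-out. The six-membered aromatic ring of carbon only, which leaves with 2H-indazol-2-yl, is therefore not required for a clearance at this level in this series. No available data bear on the reason for this result.

Still open, from the compounds shown here alone, is whether a nitrile or a simple amine on this aromatic carbon would give a similar number in this assay. Going by these compounds, the effect of the same change on the core of compound 1 also remains open.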